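This account rests on a few compounds, and the source may have more. Where it says the series, first, only, none or still open, it means among the compounds named here.

Of the compounds shown here, three built on a shared core have been tested in a functional assay on the whole organism (artery, strain albino) with Rattus norvegicus as the target, with a stated time of 60 min, at a dose of 10 mg/kg by the oral route; a higher number here means more inhibition at the dose given (going by the name of the read-out), a lower number less inhibition. Compound 1 `COc1ccc(C2N=C(SCc3ccccc3)NC(C)=C2C(=O)Nc2ccc(F)cc2)cc1OC` gives 6.2%. Compound 2 `COc1ccc(C2N=C(SCc3ccc(Cl)cc3)NC(C)=C2C(=O)Nc2ccc(F)cc2)cc1OC` gives 10.3%, and compound 3 `CC1=C(C(=O)Nc2ccc(F)cc2)C(c2ccc([N+](=O)[O-])cc2)N=C(SCc2ccccc2)N1` gives 12.3%. The step of a number 6.1 percentage points higher from compound 1 to compound 3 (within the scatter) and the step of a number 4.1 percentage points higher from compound 1 to compound 2 (within the scatter) both stay within the scatter, so compound 3 cannot be told apart from the other two in this assay. Compound 4 `CC1=C(C(=O)Nc2ccc(F)cc2)C(c2ccc([N+](=O)[O-])cc2)N=C(SCc2cccc(Cl)c2)N1` differs from compound 3 by chloro in place of hydrogen on an aromatic carbon. For the measured compounds named here, the step of a number 4.1 percentage points higher from compound 1 to compound 2 (within the scatter) is the only measured change of the same kind, chloro in place of hydrogen on an aromatic carbon, and it stayed within the scatter, so no step beyond the scatter is expected for compound 4 in this assay. Compound 4 is expected to give 14%, between 4% and 26%. This estimate means a step of a number 1.7 percentage points higher from compound 3 to compound 4 (within the scatter).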

Compound 4, a percentage reported as inhibition, in the whole organism at one dose (the size of the read-out at that dose, not a potency): 7.2%
Beside the measured number, compound 4's estimate is 6.8 percentage points above it; low and high end bracket the measured number.
By their numbers in this assay, from the lowest: compounds 1, 4, 2 and 3 (each within the scatter of the next).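

On the core of compound 3, chloro in place of hydrogen, giving the 3-chlorobenzyl group, comes with a number 5.1 percentage points lower from compound 3 to compound 4 (within the scatter) in this assay. For the compounds shown here, until now this change had been seen on one core only, and a second core also yields no step that can be read. The two steps cannot be told apart either: the same change on two cores in this assay, a number 4.1 percentage points higher (within the scatter) from compound 1 to compound 2 and a number 5.1 percentage points lower (within the scatter) from compound 3 to compound 4, 9.2 percentage points apart, within the scatter of two such steps.

As far as these compounds go, what an amine or a carboxylic acid would do in this place remains open. So does whether any group on this benzyl ring can move the number beyond the scatter.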